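The source may report more compounds than this note shows. Statements on the series, on what has been measured and on what is new or still open speak of the compounds shown alone.

Measured in a functional assay on SW-620 cells (Homo sapiens) for cytotoxicity, read by MTT assay, with a stated time of 48 h; on this read-out lower numbers stand for stronger inhibition and higher numbers for weaker inhibition:
compound 1 `CCCCCCCCCCCCCCNC(=O)[C@@H](N)[C@@H](C)O` gives 18700 nM
compound 2 `CCCCCCCCCCCCCCCCCCNC(=O)[C@@H](N)[C@@H](C)O` gives 21400 nM
compound 3 `CCCCCCCCNC(=O)[C@@H](NC(=O)c1cc2ccccc2o1)[C@@H](C)O` gives 200000 nM

Compound 2 stands second highest of the three numbers, with compound 1 nearest and compound 3 furthest. Within the data shown here, the only single-point step measured, a 1.1-fold higher number from compound 1 to compound 2 (0.06 log units; within the scatter), alters the chain alone and leaves the amine nitrogen untouched. Compound 4 `CCCCCCCCCCCCCCCCCCNC(=O)[C@@H](NC(=O)c1cc2ccccc2n1C)[C@@H](C)O` differs from compound 2 by (1-methyl-1H-indol-2-yl)carbonyl in place of hydrogen on an amine nitrogen. Among the measured compounds shown here, no measured step bears directly on this change; the nearest hint is that compound 2 gives 21400 nM, while compound 3, which carries an acyl group on the same nitrogen together with a shorter chain, gives 200000 nM. For compound 4 a step toward a higher number is therefore expected in this assay, a 2.8-fold higher number from compound 2 to compound 4 (0.45 log units; beyond the scatter), with wide uncertainty. The estimate for compound 4 is 60000 nM, range 20000 nM to 200000 nM.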

Compound 4, half-maximal inhibitory concentration: 124000 nM
Beside the measured number, compound 4's estimate is 2.1-fold (0.32 log units) below it, and the stated range covers the measured number.
By their numbers in this assay, from the lowest: compounds 1 and 2 (each within the scatter of the next); then compounds 4 and 3 (each within the scatter of the next).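

In this assay the amine nitrogen now has a direct reading: (1-methyl-1H-indol-2-yl)carbonyl in place of hydrogen gives a 5.8-fold higher number from compound 2 to compound 4 (0.76 log units; beyond the scatter) and so moves the number toward weaker inhibition. Among these compounds, the only earlier step changed the chain and stayed within the scatter, so this amine nitrogen is the first place where a single change clears it. No measured evidence bears on the reason for this step. Open, going by these compounds, is whether acetyl on the same nitrogen gives a step of similar size. Also open, on these data alone, is whether the same acyl group has a like effect on the shorter chain of compound 1.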